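A few compounds are considered here, and "the series" means these few. Any claim that something is new, unique, unknown or untested is made for them only; others in the source may bear on it.

Measured in a functional assay on cells (leukaemia cell line, Homo sapiens) for inhibition, read by sulforhodamine B assay, with a stated time of 48 h; a lower number here means that less compound is tolerated, a higher number that more compound is tolerated:
Compound 1 `O=S(=O)(Nc1ccc(Cl)c(F)c1)c1ccc(-c2cnc(C3CC3)o2)cc1`: > 100000 nM (a limit)
Compound 2 `O=S(=O)(Nc1cc(F)cc(Cl)c1)c1ccc(-c2cnc(C3CC3)o2)cc1`: > 100000 nM (a limit)

Compound 2 gives > 100000 nM, which is a limit and not a number. Compound 3 `Cc1cc(Cl)ccc1NS(=O)(=O)c1ccc(-c2cnc(C3CC3)o2)cc1` carries 4-chloro-2-methylphenyl in place of 3-chloro-5-fluorophenyl on a sulfonamide nitrogen. Within the data shown here, the only measured step bearing on this is a step that the two limits leave unreadable from compound 1 to compound 2, also a change on a sulfonamide nitrogen, and it offers no size. All that the series shows so far is the limit of > 100000 nM in this assay, at which 2 of the 2 values shown sit. No step beyond the scatter is therefore expected in this assay, and the estimated step is a number no higher from compound 2 to compound 3 (the limit leaves the size open). Compound 3 is estimated at 100000 nM, with an expected range of 30000 nM to 200000 nM.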

Compound 3, concentration lethal to 50% of the cells: > 100000 nM
Compound 3 ended at the assay's limit; the forecaster's own chance of this, stated with the estimate: 85%; the middle value lies on the limit itself.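

In this assay compound 3 gives > 100000 nM, which is a limit and not a number. Among these compounds, no step among compound 1, compound 2 and compound 3 can be read. Whether any change on a sulfonamide nitrogen shifts the read-out at all remains open, as the compounds shown offer only this: the limit of > 100000 nM in this assay, at which 3 of the 3 values shown sit.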